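This account rests on a few compounds, and the source may have more. Where it says the series, first, only, none or still open, it means among the compounds named here.

Measured in a functional assay on K562 cells (Homo sapiens) for cytotoxicity, read by flow cytometry, with a stated time of 72 h; a lower number here means a stronger inhibitor, a higher number a weaker inhibitor:
Compound 1 `Cc1ccc(S(=O)(=O)Cc2nc(Nc3ccccc3)c3ccccc3n2)cc1`: "nd(insoluble)" (no result reported)
Compound 2 `Cc1ccc(S(=O)(=O)Cc2nc(Nc3cccc(C(F)(F)F)c3)c3ccccc3n2)cc1`: > 25000 nM

Compound 1 therefore offers no number to compare. Compound 2 stands at > 25000 nM, which is a limit of this assay and not a number.

Compound 3 `Cc1ccc(S(=O)(=O)Cc2nc(Nc3ccc(F)cc3)c3ccccc3n2)cc1` has 4-fluorophenyl in place of 3-(trifluoromethyl)phenyl on a nitrogen on an aromatic ring.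

For the measured compounds named here, no measured step shows what such a swap does, so no clear gain or loss in this assay is expected. The expected change is a number no higher from compound 2 to compound 3 (the limit leaves the size open), which would not go beyond the usual scatter. For compound 3 the estimate is 25000 nM, with an expected range from 8000 nM to 60000 nM.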

Compound 3, half-maximal inhibitory concentration: > 20000 nM
Compound 3 ended at the assay's limit; the forecaster's own chance of this, stated with the estimate: 60%; the middle value does not contradict the limit.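

In this assay compound 2 and compound 3 each give only a limit, not a number, and no step can be read between them. As far as these compounds go, whether 4-fluorophenyl in place of 3-(trifluoromethyl)phenyl changes the cytotoxicity at all stays open.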